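A few compounds are considered here, and "the series" means these few. Any claim that something is new, unique, unknown or untested is made for them only; others in the source may bear on it.

Compound 1 `OC(c1ccc(Cl)cc1)(c1ccc(C(F)(F)F)cc1)c1cncnc1` and compound 2 `OC(c1ccc(Cl)cc1)(c1ccc(C(F)(F)F)cc1)c1cccnc1` share one core, and in an ADME assay on L6 cells (Rattus norvegicus) for cytotoxicity, read by resazurin assay, with a stated time of 72 h (on this read-out higher numbers stand for weaker inhibition and lower numbers for stronger inhibition), compound 1 gives 66800 nM. In this assay compound 2 gives 56400 nM. The change between the two is pyridin-3-yl in place of pyrimidin-5-yl on a saturated chain carbon bound to two aromatic carbons and an oxygen on a saturated carbon. Compound 3 `Clc1ccc(C(c2cncnc2)c2ccccc2Cl)cc1` has a different core, and how the core of compound 3 differs from the core of compound 1 is not broken down here. In this assay compound 3 gives only a limit of the assay, > 100000 nM, which is the limit of > 100000 nM in this assay, at which 1 of the 3 values shown sits.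

Compound 4 `Clc1ccc(C(c2cccnc2)c2ccccc2Cl)cc1` has not yet been measured. It differs from compound 3 by pyridin-3-yl in place of pyrimidin-5-yl on a saturated chain carbon bound to two aromatic carbons, the same kind of change as from compound 1 to compound 2, though here the place is a saturated chain carbon bound to two aromatic carbons, without the oxygen on a saturated carbon of the earlier pair. The step from compound 3 to compound 4 is expected to be a step that the limit leaves unreadable from compound 3 to compound 4 because the earlier step of this kind was a 1.2-fold lower number from compound 1 to compound 2 (0.07 log units; within the scatter). Compound 4 is therefore estimated to give about 110000 nM in this assay, quite possibly again only as a limit.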

Compound 4, half-maximal inhibitory concentration: 62300 nM
For compound 4 the middle estimate is 1.8-fold (0.25 log units) above the measured one, within the range that was stated.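

In this assay, putting pyridin-3-yl in place of pyrimidin-5-yl on a saturated chain carbon bound to two aromatic carbons gives an at least 1.6-fold lower number from compound 3 to compound 4 (0.20 log units; that floor lies within the scatter). Set beside the same change on the other core, this gives only a partial comparison: the same change on two cores in this assay, a 1.2-fold lower number (0.07 log units; within the scatter) from compound 1 to compound 2 and an at least 1.6-fold lower number (0.20 log units; that floor lies within the scatter) from compound 3 to compound 4; the limit leaves it open whether they differ The value of compound 3 is a limit and not a number, so the full size of this step stays unknown, and the data neither show that the change carries over from one core to the other with the same size nor show that it differs: the limit of > 100000 nM in this assay, at which 1 of the 4 values shown sits.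

The compounds shown hold only pyrimidin-5-yl or pyridin-3-yl at this place, which leaves open what a plain phenyl ring or a ring bearing an amine would give in this assay. Also open, from the compounds shown here alone, is how the same change would read on a core carrying a carboxylic acid, and on a pair in which both values are true numbers and not limits.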